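The source may report more compounds than this note shows. Statements on the series, on what has been measured and on what is new or still open speak of the compounds shown alone.

Compound 1 `CCc1cnc(N2CCC(n3nnc4cc(-c5ccc(S(C)(=O)=O)cc5)ncc43)CC2)nc1` is the reference point of the set. In a functional assay on HEK293 cells for agonist activity at Glucose-dependent insulinotropic receptor (Homo sapiens), read by HTRF and cAMP accumulation, with a stated time of 30 min (a lower number here means that less compound is needed, a higher number that more compound is needed for the effect), compound 1 gives 21 nM. Compound 2 `CCc1cnc(N2CCC(n3nnc4cc(-c5ccc(S(C)(=O)=O)c(F)c5)ncc43)CC2)nc1` carries one change against it, (fluoro in place of hydrogen on an aromatic carbon), and in this assay compound 2 gives 9 nM; the resulting step is a 2.3-fold lower number from compound 1 to compound 2 (0.37 log units; beyond the scatter).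

Compound 3 `CCNC(=O)c1ccc(-c2cc3nnn(C4CCN(c5ncc(CC)cn5)CC4)c3cn2)c(F)c1` rests on a different core; how that core differs from the core of compound 1 is not broken down here. In this assay compound 3 gives 15 nM, a number that sits within the scatter of both compound 1 and compound 2.

Compound 4 `CCNC(=O)c1cc(F)c(-c2cc3nnn(C4CCN(c5ncc(CC)cn5)CC4)c3cn2)cc1F` has not yet been measured. It differs from compound 3 by fluoro in place of hydrogen on an aromatic carbon. This is the same kind of change as that from compound 1 to compound 2, but not the same: there the fluoro entered ortho to a methylsulfonyl group and meta to a large group, whereas here it enters ortho to an ethylcarbamoyl group, meta to a large group and para to a fluoro group.

Because the earlier step of a 2.3-fold lower number from compound 1 to compound 2 (0.37 log units; beyond the scatter) was modest and the surroundings differ, only a similar or smaller step is expected from compound 3 to compound 4, namely a 1.7-fold lower number from compound 3 to compound 4 (0.22 log units; within the scatter). Compound 4 is therefore estimated in this assay at 9 nM, between 4 nM and 22 nM.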

Compound 4, half-maximal effective concentration: 2 nM
For compound 4 the middle estimate is 4.5-fold (0.65 log units) above the measured one, outside the stated range (below it).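

In this assay the fluoro in place of hydrogen on an aromatic carbon lowers the number again on the second core, a 7.5-fold lower number from compound 3 to compound 4 (0.88 log units; beyond the scatter), so the direction of the change carries over but its size does not: the same change on two cores in this assay, a 2.3-fold lower number (0.37 log units; beyond the scatter) from compound 1 to compound 2 and a 7.5-fold lower number (0.88 log units; beyond the scatter) from compound 3 to compound 4, 3.2-fold (0.51 log units) apart, beyond the scatter of two such steps. The change can therefore be expected to help on both cores shown, but the step from one core cannot be taken as a measure of the step on the other. Going by these compounds alone, with only two pairs, the data do not separate the effect of the core from that of the local surroundings, since the new fluoro in compound 4 enters ortho to an ethylcarbamoyl group and para to a fluoro group, whereas compound 2 carries a methylsulfonyl group instead.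

The compounds shown leave open whether a chloro or a methoxy group on that same carbon would lower the number as fluoro does. They also leave open what a longer chain on the amide nitrogen, or a carboxylic acid in place of the ethylcarbamoyl group, would do.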